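From Ethylsulfanyl to Isopropylsulfanyl: an Expected Potency

A few compounds are considered here, and "the series" means these few. Any claim that something is new, unique, unknown or untested is made for them only; others in the source may bear on it.

In a functional assay for inhibition of sodium/hydrogen exchanger (Oryctolagus cuniculus) (on this read-out lower numbers stand for stronger inhibition and higher numbers for weaker inhibition), compound 1 `Cc1cc(-c2ccc(Cl)cc2Cl)c(S(C)(=O)=O)cc1C(=O)N=C(N)N` gives 42 nM, while compound 2 `CCSc1cc(C)c(C(=O)N=C(N)N)cc1S(C)(=O)=O` gives 5.9 nM. The step reads a 7.1-fold lower number from compound 1 to compound 2 (0.85 log units; beyond the scatter), so compound 2 holds the lower of the two numbers. Compound 3 `Cc1cc(SC(C)C)c(S(C)(=O)=O)cc1C(=O)N=C(N)N` differs from compound 2 by methyl in place of hydrogen on a saturated chain carbon bound to a saturated chain carbon and a sulfur. No measured step touches the ethylsulfanyl chain itself; the single step shown swaps the whole group, which says little about one added methyl. In this assay the expected step is a 1.0-fold higher number from compound 2 to compound 3 (0.01 log units; within the scatter), within the scatter. Compound 3 is estimated at 6 nM, with a range from 2 nM to 18 nM.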

Compound 3, half-maximal inhibitory concentration: 12 nM
Estimate against measurement, compound 3: 2.0-fold (0.30 log units) below; the measured number falls inside the stated range.
By their numbers in this assay, from the lowest: compound 2; then compound 3; then compound 1.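

In this assay the added methyl is not neutral: the step is a 2.0-fold higher number from compound 2 to compound 3 (0.31 log units; beyond the scatter) and it lies beyond the scatter, so this chain carbon responds to a single extra carbon. Isopropylsulfanyl still improves on 2,4-dichlorophenyl at the aromatic carbon, with a 3.5-fold lower number from compound 1 to compound 3 (0.54 log units; beyond the scatter) as the step, though by less than ethylsulfanyl does. Nothing shown gives a reason for either step.

Open, from the compounds shown here alone, is how a longer chain such as propylsulfanyl, or a shorter methylsulfanyl, would read here. Going by these compounds, a further branched tert-butylsulfanyl or an amine in place of the sulfur chain also remains open.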